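A few compounds are considered here, and "the series" means these few. Any claim that something is new, unique, unknown or untested is made for them only; others in the source may bear on it.

Compound 1 `CNC(=O)c1cc(Oc2ccc3nc(Nc4ccccc4Br)ncc3c2)ccn1` and compound 2 `CNC(=O)c1cc(Oc2ccc3nc(Nc4ccc(Br)cc4)ncc3c2)ccn1` share one core and differ only in 4-bromophenyl in place of 2-bromophenyl on a nitrogen on an aromatic ring. In a physicochemical assay for solubility, at pH 7 (a higher number here means a more soluble compound, a lower number a less soluble compound), compound 1 gives < 1000 nM, which is a limit of the assay rather than a number. In this assay compound 2 gives < 1000 nM, again a limit. The step that the two limits leave unreadable from compound 1 to compound 2 cannot be sized because the limit of < 1000 nM in this assay, at which 2 of the 2 values shown sit, holds both values. Compound 3 `CNC(=O)c1cc(Oc2ccc3nc(Nc4ccc(C(C)C)cc4)ncc3c2)ccn1` is still to be measured; it differs from compound 2 by isopropyl in place of bromo on an aromatic carbon. Within the data shown here, the single measured step concerns a different change and has no readable size, so it gives no direction for compound 3. Compound 3 is expected to give 500 nM, between 100 nM and 1500 nM, with a fair chance that only a limit is reported. That expectation amounts to an estimated step that the limit leaves unreadable from compound 2 to compound 3.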

Compound 3, solubility: < 1000 nM
Compound 3: only a limit was reported; the forecaster's own chance of this, stated with the estimate: 80%; the middle value does not contradict the limit.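

Compound 3 also returns only a limit, so no step among compound 1, compound 2 and compound 3 can be read, because all three rest at one limit: the limit of < 1000 nM in this assay, at which 3 of the 3 values shown sit.

Going by these compounds, how far apart these compounds really lie in this assay stays open.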